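A Longer Nitrile Chain on a Flat Baseline

This account rests on a few compounds, and the source may have more. Where it says the series, first, only, none or still open, it means among the compounds named here.

Compound 1 `COc1ccc2cc(-c3ccccc3)c(O)nc2c1`: 10000 nM
Compound 2 `COc1ccc(-c2cc3c(OC)cc(OC)cc3n(CC#N)c2=O)cc1`: 10000 nM

In a functional assay on A 172 cells (Homo sapiens) for cytotoxicity, read by colorimetric assay and MTT assay (a lower number here means a stronger inhibitor, a higher number a weaker inhibitor), compound 2 gives 10000 nM, level with compound 1 at 10000 nM at the digits shown, so the two stand within the usual scatter of each other.

Compound 3 `COc1ccc(-c2cc3c(OC)cc(OC)cc3n(CCC#N)c2=O)cc1` has not yet been measured. It departs from compound 2 in a single place, (cyanomethyl in place of cyano on a saturated chain carbon bound to an aromatic nitrogen). In words, cyanomethyl stands in place of cyano on a saturated chain carbon bound to an aromatic nitrogen, which can also be read as cyanomethyl to 2-cyanoethyl.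

Within the data shown here, the measured compounds include no pair that differs in one place, so this change has no direct precedent here. The closest guide is compound 2 at 10000 nM, and no step beyond the scatter, in either direction, is expected in this assay. The expected change is no change at the digits printed from compound 2 to compound 3 (within the scatter). For compound 3 the estimated value is 10000 nM, with an expected range from 5000 nM to 20000 nM.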

Compound 3, half-maximal inhibitory concentration: 10000 nM
Compound 3: the middle estimate sits on the measured number at the digits printed, and the stated range covers the measured number.
By their numbers in this assay, from the lowest: compounds 1, 2 and 3 (each within the scatter of the next).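

Among these compounds, the change from cyano to cyanomethyl on a saturated chain carbon bound to an aromatic nitrogen gives this series its only direct step in this assay, and that step reads no change at the digits printed from compound 2 to compound 3 (within the scatter) in full. This shows that, on the core shared by these two compounds, moving from cyanomethyl to 2-cyanoethyl does not separate them: compound 2 gives 10000 nM and compound 3 gives 10000 nM in this read-out. Nothing else available here bears on this result or accounts for it.

Going by these compounds, whether an amine, a carboxylic acid or a longer chain carried at this same place would give a number apart from these remains open. A single step also leaves open whether the change from cyano to cyanomethyl would read the same way on a different core, or with other groups elsewhere on the shared core.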